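The source may hold more compounds than are shown below. What is called first, only, known or untested is meant among the compounds shown, and "the series" means these compounds.

Compound 3 `C=CC[C@@H]1C[C@@H](c2ccc(Cl)c(Cl)c2)[C@H](NC(=O)c2cc(-c3c(Cl)cnn3C)c(Cl)o2)CN1` is one of three compounds whose activity in a functional assay on HCT-116 cells (Homo sapiens) for antiproliferative activity, read by sulforhodamine B assay, with a stated time of 72 h (a lower number here means a stronger inhibitor, a higher number a weaker inhibitor), is known. In this assay compound 3 gives 780 nM. Compound 1 `Cn1ncc(Cl)c1-c1cc(C(=O)N[C@@H]2CN[C@H](CCn3cncn3)C[C@H]2c2ccc(Cl)c(Cl)c2)oc1Cl` carries a (1H-1,2,4-triazol-1-yl)methyl group where compound 3 carries vinyl, and in this assay compound 1 gives 560 nM; the step of a 1.4-fold higher number from compound 1 to compound 3 (0.14 log units; within the scatter) lies within the scatter. Compound 2 `O=C(N[C@@H]1CNCC[C@H]1c1ccc(Cl)cc1)c1ccc(-c2ncnc3c2CCC3O)s1` belongs to a different series of the shared core, and in this assay compound 2 gives 23000 nM, far from both others. On the numbers shown, compound 3 sits second of three, close to compound 1 and far from compound 2.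

Compound 4 `Cn1ncc(Cl)c1-c1cc(C(=O)N[C@@H]2CN[C@H](CC(N)=O)C[C@H]2c2ccc(Cl)c(Cl)c2)oc1Cl` differs from compound 3 in one place: carbamoyl in place of vinyl on a saturated chain carbon bound to a saturated ring carbon. Among the measured compounds shown here, the only measured step that bears on this change is the one from compound 1 to compound 3, an exchange at the same saturated chain carbon bound to a saturated ring carbon, and its size a 1.4-fold higher number from compound 1 to compound 3 (0.14 log units; within the scatter) was within the scatter. For the measured compounds named here, no measured step speaks to a carbamoyl at this place. On that basis the expected step of a 1.2-fold lower number from compound 3 to compound 4 (0.08 log units; within the scatter) is none beyond the scatter. Compound 4 is therefore estimated at 650 nM, with a range from 250 nM to 1700 nM.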

Compound 4, half-maximal inhibitory concentration: 650 nM
For compound 4 middle estimate and measured number coincide at the digits printed; the range from low to high includes it.
By their numbers in this assay, from the lowest: compounds 1, 4 and 3 (each within the scatter of the next); then compound 2.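

In this assay, the saturated chain carbon bound to a saturated ring carbon has now been shown with a third group, and the new comparisons stay within the scatter: carbamoyl in place of vinyl (a 1.2-fold lower number from compound 3 to compound 4 (0.08 log units; within the scatter)) and carbamoyl in place of (1H-1,2,4-triazol-1-yl)methyl (a 1.2-fold higher number from compound 1 to compound 4 (0.06 log units; within the scatter)). The earlier pair had shown only that two groups without a hydrogen-bond donor could be exchanged here with no step beyond the scatter, whereas carbamoyl is counted with a hydrogen-bond donor and a hydrogen-bond acceptor and still gives none, so among compounds 1, 3 and 4 the read-out does not separate these groups. No measured information is available to explain this result.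

The compounds shown leave open whether a primary amine, a carboxylic acid or a longer chain carrying either of them on this same carbon would give a step beyond the scatter. They also leave open whether the same exchanges would stay within the scatter on the core of compound 2, which differs from the others in more than one place.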